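The source may report more compounds than this note shows. Statements on the series, on what has been measured and on what is new or still open speak of the compounds shown alone.

Measured in a toxicity assay on HeLa cells (Homo sapiens) for cytotoxicity, read by MTT assay, with a stated time of 24 h; on this read-out lower numbers stand for stronger inhibition and higher numbers for weaker inhibition:
- Compound 1 `Cc1ncc([N+](=O)[O-])n1CC(O)CSC(=S)N1CCN(c2ccccn2)CC1`: 2970000 nM
- Compound 2 `Cc1ncc([N+](=O)[O-])n1CC(O)CSC(=S)N1CCN(C(=O)OC(C)(C)C)CC1`: 689000 nM

Compound 2 has the lower of these two numbers, and so the stronger inhibition. The next compound, compound 3 `Cc1nc([N+](=O)[O-])cn1CC(O)CSC(=S)N1CCN(C(=O)OC(C)(C)C)CC1`, has the same atoms as compound 2, joined differently: 2-methyl-4-nitro-1H-imidazol-1-yl in place of 2-methyl-5-nitro-1H-imidazol-1-yl on a saturated chain carbon, two bonds along the chain from an oxygen on a saturated carbon. Going by the values given here, only one measured step is available as a guide, a 4.3-fold lower number from compound 1 to compound 2 (0.63 log units; beyond the scatter). That change, tert-butoxycarbonyl in place of pyridin-2-yl, lies at a different place in the molecule, so it bears on this question only indirectly. Among the compounds with values here, it suggests the size a single change can reach here, but no measured pair tests where the nitro group sits. No direction can be drawn from the data, so a small shift is expected in this assay. The expected change, a 1.2-fold higher number from compound 2 to compound 3 (0.06 log units; within the scatter), is an estimate that stays modest. For compound 3 the estimated value is 800000 nM, with an expected range of 300000 nM to 2200000 nM.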

Compound 3, half-maximal inhibitory concentration: > 5000000 nM
Compound 3: only a limit was reported; the forecaster's own chance of this, stated with the estimate: 10%; middle value at least 6.2-fold (0.79 log units) from the limit.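

In this assay, putting 2-methyl-4-nitro-1H-imidazol-1-yl in place of 2-methyl-5-nitro-1H-imidazol-1-yl gives an at least 7.2-fold higher number from compound 2 to compound 3 (0.86 log units; beyond the scatter), so the way this group is joined matters here even though the atoms stay the same. Going by these compounds alone, the earlier step changed a group on an amine nitrogen in a ring, which makes this the first measured pair to test where the nitro group sits, and the 2-methyl-5-nitro-1H-imidazol-1-yl form gives the stronger inhibition. The value of compound 3 is a limit and not a number: the limit of > 5000000 nM in this assay, at which 1 of the 3 values shown sits.

Within the data shown here, only one pair tests this change, so it stays open whether the same holds with pyridin-2-yl in place of tert-butoxycarbonyl. Also open, from the compounds shown here alone, is how an amine or a carboxylic acid in place of the nitro group would behave in this assay.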